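Alkyl Chain Length at the Amide Nitrogen and Growth Inhibition

The source may report more compounds than this note shows. Statements on the series, on what has been measured and on what is new or still open speak of the compounds shown alone.

Two amides built on one shared core have been measured in a functional assay on the whole organism for inhibition, with Brassica rapa subsp. chinensis as the target, with a stated time of 3 days, tested at 100 ppm; on this read-out higher numbers stand for more inhibition of growth at the one concentration tested and lower numbers for less inhibition of growth. Compound 1 `CCCCCCCCCCCCCCCCNC(=O)/C=C/c1ccccc1` bears a long saturated chain on the amide-type nitrogen, and in this assay compound 1 gives 20%. Compound 2 `CCCNC(=O)/C=C/c1ccccc1` bears a short chain on the same nitrogen, and in this assay compound 2 gives 15%. Compound 2 thus holds the smaller of the two numbers shown, but the gap to compound 1 lies within the scatter, so the two values stand side by side rather than apart.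

Compound 3 `CCCCCCCCNC(=O)/C=C/c1ccccc1` has not yet been measured. Its difference from compound 2 is pentyl in place of hydrogen on a saturated chain carbon, three bonds along the chain from an amide-type nitrogen; the same difference, cut one bond further out, reads methyl to hexyl. Among the compounds with values here, with no step between measured compounds to lean on, and with the short chain of compound 2 and the long chain of compound 1 yielding values within the scatter of each other, the step from compound 2 to compound 3 is expected to be no larger than the scatter, in no clear direction, as a number 3 percentage points higher from compound 2 to compound 3 (within the scatter). Compound 3 is therefore expected to give about 18%, with a range from 5% to 35%.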

Compound 3, percent growth inhibition at one concentration: 34%
Beside the measured number, compound 3's estimate is 16 percentage points below it; measured number inside the range.
By their numbers in this assay, from the lowest: compounds 2 and 1 (each within the scatter of the next); then compound 3.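

In this assay, the chain on the amide-type nitrogen now matters, which the first two compounds alone did not show. Pentyl in place of hydrogen on a saturated chain carbon, three bonds along the chain from an amide-type nitrogen, gives a number 19 percentage points higher from compound 2 to compound 3 (beyond the scatter), and hydrogen in place of octyl on a saturated chain carbon, eight bonds along the chain from that nitrogen, gives a number 14 percentage points higher from compound 1 to compound 3 (beyond the scatter), so extending the short chain and cutting back the long chain both end at the higher number of compound 3. Across these three compounds the number therefore does not follow chain length in one direction, and the data offer no measurement that accounts for the rise.

Three chain lengths cannot fix where the highest number lies, and a hexyl or a dodecyl chain on the same nitrogen would show whether the rise around compound 3 is broad or narrow. Going by these compounds, it also remains open whether the step depends on an unbranched saturated chain or would persist with a branched chain, or with a chain ending in a hydroxyl group.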